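A few compounds are considered here, and "the series" means these few. Any claim that something is new, unique, unknown or untested is made for them only; others in the source may bear on it.

- Compound 1 `CCN(c1ccc(C#N)c(Cl)c1)c1cc(-c2cnc3ccccc3c2)ccc1C` gives 25300 nM
- Compound 2 `CCN(c1ccc(C#N)c(Cl)c1)c1cc(-n2cnc3ccccc32)ccc1C` gives 8560 nM

For the measured compounds named here, in a functional assay on VCaP cells (Homo sapiens) for antiproliferative activity, read by CCK-8 assay, with a stated time of 6 days (a higher number here means a weaker inhibitor, a lower number a stronger inhibitor), compound 2 (8560 nM) holds the lowest of the two numbers so far, and its gap to compound 1 lies beyond the scatter. Compound 3 `CCN(c1ccc(C#N)c(Cl)c1)c1cc(-c2ccnn2C)ccc1C` keeps the shared core but carries 1-methyl-1H-pyrazol-5-yl in place of 1H-benzimidazol-1-yl on an aromatic carbon. Going by the values given here, no measured pair differs in one place only, so the size of this change cannot be read from the data. Among the compounds with values here, the only guide is the range set by compound 2 (8560 nM) and compound 1 (25300 nM). In this assay no change beyond the scatter is expected, though the expectation leans towards a higher number, an estimated move (a 1.6-fold higher number from compound 2 to compound 3 (0.21 log units; within the scatter)) in the direction of weaker inhibition. For compound 3 the expected value is 14000 nM with an estimated range from 4000 nM to 40000 nM in this measurement.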

Compound 3, half-maximal inhibitory concentration: 1670 nM
Compound 3: the middle estimate sits 8.4-fold (0.92 log units) above what was measured; the whole stated range lies above it.
By their numbers in this assay, from the lowest: compound 3; then compound 2; then compound 1.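

In this assay, putting 1-methyl-1H-pyrazol-5-yl in place of 1H-benzimidazol-1-yl on this aromatic carbon, para to a methyl group, gives a 5.1-fold lower number from compound 2 to compound 3 (0.71 log units; beyond the scatter), which shows that the number at this position responds to the group it carries. The entering group has one aromatic ring instead of two and 6 heavy atoms instead of 9, while the counts of hydrogen-bond donors and acceptors stay the same, so the lower number comes with a smaller group and no change in those counts. Nothing measured here explains the drop.

This single step cannot separate the effect of losing the six-membered ring from that of the methyl group on the pyrazole. The compounds shown leave open how a pyrazole with an ethyl group in place of that methyl, or an amine or a carboxylic acid at this position, would read in this assay.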